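Working notes: aryl substituent swap, compound 2 to compound 3

The source may hold more compounds than are shown below. What is called first, only, known or untested is meant among the compounds shown, and "the series" means these compounds.

Measured so far:
compound 1, `Nc1scc(-c2cc(C(F)(F)F)cc(C(F)(F)F)c2)c1C(=O)c1ccc(Cl)cc1`: 5.46
compound 2, `Nc1scc(-c2cccc(F)c2)c1C(=O)c1ccc(Cl)cc1`: 5.88

In an assay on isolated protein with adenosine receptor A1 (Homo sapiens) as the target, read by ERK phosphorylation (on this read-out lower numbers stand for lower potency and higher numbers for higher potency (the scale is a negative logarithm)), compound 2 stands highest of the two numbers, and compound 1 lies below it by a gap beyond the usual scatter. Compound 3, `Nc1scc(-c2cccc(C(F)(F)F)c2)c1C(=O)c1ccc(Cl)cc1`, is not yet measured. It differs from compound 2 by trifluoromethyl in place of fluoro on an aromatic carbon, the change sitting on an aromatic carbon of a six-membered aromatic ring of carbon only, meta to a large group. Within the data shown here, no pair of measured compounds isolates this single swap, so its size is not known directly. Compound 1, with two trifluoromethyl groups on that ring, gives 5.46 in this assay, which only shows that the doubly substituted ring reads lower than the fluoro ring of compound 2. Among the measured compounds shown here, for the single trifluoromethyl of compound 3 a small step downward is expected, a number 0.18 log units lower from compound 2 to compound 3 (within the scatter), near the edge of the scatter. Compound 3 is therefore estimated at 5.7, with a range from 5.25 to 6.15.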

Compound 3, negative logarithm of the antagonist equilibrium constant: 5.74
Estimate against measurement, compound 3: 0.04 log units below; the measured number falls inside the stated range.
By their numbers in this assay, from the lowest: compounds 1, 3 and 2 (each within the scatter of the next, the first and the last beyond it).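

In this assay, among these compounds, trifluoromethyl in place of fluoro on an aromatic carbon gives a number 0.14 log units lower from compound 2 to compound 3 (within the scatter) and so isolates this swap for the first time, showing that at this place, meta to a large group, the exchange does not move the reading beyond the scatter. Hydrogen in place of trifluoromethyl on an aromatic carbon gives a number 0.28 log units higher from compound 1 to compound 3 (within the scatter) and shows that removing one of the two trifluoromethyl groups of compound 1 also stays inside the scatter. No measurement at hand accounts for either step.

Among the compounds shown here, all substituents compared at this place so far carry fluorine, so it remains open whether the reading stays this flat with an amine, a carboxylic acid or a methoxy group there. As far as these compounds go, whether any such group would shift the number beyond the scatter also remains open.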